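Swapping nitro for fluoro on compound 1

A few compounds are considered here, and "the series" means these few. Any claim that something is new, unique, unknown or untested is made for them only; others in the source may bear on it.

Measured so far:
- compound 1, `Cc1cccc(Cn2c(CN3CCN(C(=O)c4ccc([N+](=O)[O-])cc4)CC3)nc3ccccc32)c1`: 24.3%
- compound 2, `Cc1cccc(Cn2c(OC3CCN(C(=O)c4ccco4)CC3)nc3ccccc32)c1`: 68.3%
- compound 3, `O=C(C1CC1)N1CCN(Cc2nc3ccccc3n2Cc2ccccc2F)CC1`: 40.7%

Of the compounds shown here, three have been tested in an assay on isolated protein for inhibition of aldehyde dehydrogenase 1A1 (Homo sapiens), read by spectrophotometry, tested at 10 uM; on this read-out higher numbers stand for more inhibition at the one concentration tested (going by the name of the read-out) and lower numbers for less inhibition. Compound 1 gives 24.3%, the lowest of the three numbers. The nearest is compound 3, whose value of 40.7% lies beyond the scatter above it, and compound 2, with 68.3%, stands furthest above, again beyond the scatter. Since these three differ from one another in more than one place, the numbers alone show only where each stands.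

The next compound, compound 4 with structure `Cc1cccc(Cn2c(CN3CCN(C(=O)c4ccc(F)cc4)CC3)nc3ccccc32)c1`, differs from compound 1 in a single place: fluoro in place of nitro on an aromatic carbon. The change sits on an aromatic carbon of a six-membered aromatic ring of carbon only, para to a large group, and the whole of the molecule otherwise stays the same.

Within the data shown here, no step between two measured compounds is available to guide this change. A modest rise in this assay is expected, though one that could well stay within the scatter. Compound 4 is estimated at 30%, within a range from 12% to 50%, an expected step of a number 5.7 percentage points higher from compound 1 to compound 4 (within the scatter).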

Compound 4, a percentage reported as inhibition, at one concentration (the size of the read-out at that concentration, not a potency): 27.1%
Compound 4: middle estimate off by 2.9 percentage points, on the high side; the range from low to high includes it.
By their numbers in this assay, from the lowest: compounds 1 and 4 (each within the scatter of the next); then compound 3; then compound 2.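

In this assay, the exchange of nitro for fluoro on this aromatic carbon gives a number 2.8 percentage points higher from compound 1 to compound 4 (within the scatter), so the two compounds cannot be told apart on this read-out. Among these compounds, this is the first comparison that changes only one place, and it concerns the group para to a large group on the six-membered aromatic ring. Here three heavy atoms, two of them counted as hydrogen-bond acceptors, give way to a single fluorine with no hydrogen-bond acceptor counted, and the read-out at the one concentration tested shows no difference beyond the usual scatter. Nothing available explains why these two groups read alike.

Whether this position would respond to a group of another kind, such as an amine, a carboxylic acid or a longer carbon chain, remains open, since nitro and fluoro are the only two groups shown there. On these data alone, compound 2 and compound 3 each differ from compound 1 in more than one place, so which of those differences goes with their separate standing also remains open.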